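Sulfonamide to aryl sulfone: an expected recovery of potency

The source may report more compounds than this note shows. Statements on the series, on what has been measured and on what is new or still open speak of the compounds shown alone.

Compound 1 `O=C(NCc1ccncc1)Nc1ccc(S(=O)(=O)Nc2ccccc2)cc1`: 410 nM
Compound 2 `NS(=O)(=O)c1ccc(NC(=O)NCc2ccncc2)cc1`: 14300 nM

In an assay on isolated protein for activation of Nicotinamide phosphoribosyltransferase (Homo sapiens) (on this read-out lower numbers stand for an effect already at smaller amounts and higher numbers for an effect only at larger amounts of compound), compound 2 stands highest of the two measured numbers, and its nearest neighbour is compound 1. Compound 3 `O=C(NCc1ccncc1)Nc1ccc(S(=O)(=O)c2ccc(Cl)cc2)cc1` differs from compound 2 by 4-chlorophenyl in place of amino on a sulfonyl sulfur. Within the data shown here, one measured step bears on this: a 35-fold higher number from compound 1 to compound 2 (1.54 log units; beyond the scatter), a large loss when an aromatic ring left the sulfonamide. Returning an aromatic ring, now directly on the sulfur, is expected to recover most of that loss, so a large step downward is expected, a 20-fold lower number from compound 2 to compound 3 (1.31 log units; beyond the scatter). Compound 3 is therefore estimated at 700 nM, within 150 nM to 3500 nM.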

Compound 3, half-maximal effective concentration: 126 nM
Compound 3: the middle estimate sits 5.6-fold (0.74 log units) above what was measured, outside the stated range (below it).
By their numbers in this assay, from the lowest: compound 3; then compound 1; then compound 2.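

Placing 4-chlorophenyl on the sulfonyl sulfur gives a 110-fold lower number from compound 2 to compound 3 (2.05 log units; beyond the scatter) and shows that an aromatic ring need not be linked through a sulfonamide nitrogen to give a low number. Replacing anilino with 4-chlorophenyl also gives a 3.3-fold lower number from compound 1 to compound 3 (0.51 log units; beyond the scatter) and so goes beyond the ring-bearing sulfonamide. Nothing shown explains this gain.

On these data alone, what a plain phenyl or a saturated cyclohexyl group on the sulfur would give remains open. The share of the chlorine in this result therefore cannot be told.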